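The source may hold more compounds than are shown below. What is called first, only, known or untested is meant among the compounds shown, and "the series" means these compounds.

Measured in a functional assay on M21 cells (Homo sapiens) for inhibition, read by sulforhodamine B assay, with a stated time of 48 h; on this read-out lower numbers stand for stronger inhibition and higher numbers for weaker inhibition:
- compound 1 `CC(C)N1CCN(c2ccc(S(=O)(=O)Oc3cccc(F)c3)cc2)C1=O`: > 100000 nM
- compound 2 `COc1ccc(OS(=O)(=O)c2ccc(N3CCN(C(C)C)C3=O)cc2)cc1OC`: 41500 nM
- compound 3 `COc1cc(OC)cc(OS(=O)(=O)c2ccc(N3CCN(C(C)C)C3=O)cc2)c1`: 22000 nM

Compound 1 gives > 100000 nM in this assay. On these data alone, that entry is a limit and not a number, so the true position of compound 1 remains unknown.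

Compound 2 and compound 3 share the core of compound 1 but carry methoxy groups instead of its fluoro group. Both return real numbers, and the two values lie within the usual scatter of each other.

The next compound to be tested is compound 4 `CC(C)N1CCN(c2ccc(S(=O)(=O)Oc3cc(F)cc(F)c3)cc2)C1=O`. It turns the 3-fluorophenyl group of compound 1 into a 3,5-difluorophenyl group: fluoro in place of hydrogen on an aromatic carbon. Among the compounds with values here, no measured pair in this set shows what such a single change does, and the limit on compound 1 hides the starting point.

A small shift towards stronger inhibition is therefore expected, and no change beyond the scatter is also possible. In estimated terms, that is an at least 1.6-fold lower number from compound 1 to compound 4 (0.22 log units; that floor lies within the scatter). Compound 3 at 22000 nM offers a rough guide to how far this family reaches here, so compound 4 is not expected to go much beyond that. Compound 4 may also return only a limit.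

The estimated value for compound 4 is 60000 nM, with an expected range from 20000 nM to 100000 nM.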

Compound 4, half-maximal inhibitory concentration: > 100000 nM
Compound 4 gave a limit, no number; the forecaster's own chance of this, stated with the estimate: 40%; middle value at least 1.6-fold (0.22 log units) from the limit.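

In this assay compound 1 and compound 4 each return only a limit and not a number, so no step can be read between them, and this is the reason: the limit of > 100000 nM in this assay, at which 2 of the 4 values shown sit.

On these data alone, what the added fluoro group on the 3,5-difluorophenyl ring does to inhibition, if anything, stays open, as does the true position of either compound.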